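The source may hold more compounds than are shown below. What is called first, only, known or untested is meant among the compounds shown, and "the series" means these compounds.

Notes on the series in a functional assay on the whole organism (plasma, strain Sprague-Dawley) with Rattus norvegicus as the target, with a stated time of 2 h, at a dose of 100 mg/kg by the oral route; on this read-out lower numbers stand for a weaker effect and higher numbers for a stronger effect at the one dose given.

Compound 1 `c1ccc(C(/N=C2\CCCCCCN2)C2CC2)cc1` carries a cyclopropyl group on the saturated chain carbon bound to an aromatic carbon and a double-bonded nitrogen; in this assay compound 1 gives 58%, the higher of the two numbers recorded so far. Compound 2 `c1ccc(C(/N=C2\CCCCN2)c2ccco2)cc1` has a different core and a furan-2-yl group in that same place; in this assay compound 2 gives 27%. Going by the values given here, the two compounds differ in more than one place, so no single step connects them; their values show compound 1 well ahead of compound 2, by a margin beyond the scatter.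

Compound 3 `c1ccc(C(/N=C2\CCCCCCN2)c2cccs2)cc1` keeps the core of compound 1. The change is thiophen-2-yl in place of cyclopropyl on a saturated chain carbon bound to an aromatic carbon and a double-bonded nitrogen. Among the compounds with values here, no measured pair isolates this change. Within the data shown here, the only other five-membered aromatic group in the set, on compound 2, sits with a weaker value, but on a different core, so it gives no clean step. The expected step of a number 13 percentage points lower from compound 1 to compound 3 (beyond the scatter) is therefore small and downward, possibly within the scatter. Compound 3 is estimated at 45%, with a range from 20% to 70%.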

Compound 3, a percentage reported as inhibition, in the whole organism at one dose (the size of the read-out at that dose, not a potency): 41%
For compound 3 the middle estimate is 4 percentage points above the measured one; the range from low to high includes it.
By their numbers in this assay, from the lowest: compound 2; then compound 3; then compound 1.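

Going by these compounds alone, with thiophen-2-yl in place of cyclopropyl on a saturated chain carbon bound to an aromatic carbon and a double-bonded nitrogen, this assay gives a number 17 percentage points lower from compound 1 to compound 3 (beyond the scatter) on the core of compound 1, the first single-place reading at this position. The position therefore responds to the group it carries, and the five-membered aromatic ring does not abolish the read-out: compound 3 still gives 41% at the one dose used. Nothing measured here accounts for the step, which stands as one observation of the size of the effect at that dose, not as a potency.

From the compounds shown here alone, whether the drop follows from the larger ring, its aromatic character or the sulfur atom stays open, and it remains unknown how an open chain such as isopropyl, a saturated ring such as cyclohexyl or an amine would read at this position on the core of compound 1. Steps involving compound 2 cannot be read, as it differs from each of the other compounds in more than one place, so the contribution of the core remains unresolved.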